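Acylated aminopyrazoles against a kinase: an acyl chain extension

The source may hold more compounds than are shown below. What is called first, only, known or untested is meant among the compounds shown, and "the series" means these compounds.

Compound 1 `Cc1[nH]nc(N)c1-c1cccc(OC(F)(F)F)c1` carries a free ring nitrogen and a trifluoromethoxyphenyl on the shared core. In an assay on Sf9 cells for inhibition of inhibitor of nuclear factor kappa-B kinase subunit epsilon (Homo sapiens), read by ADP-Glo, with a stated time of 60 min (a lower number here means a stronger inhibitor, a higher number a weaker inhibitor), compound 1 reports only a limit of the assay, > 100000 nM. Compound 2 `CCC(=O)n1nc(C)c(-c2ccc(Cl)c(Cl)c2)c1N` bears a propanoyl on a ring nitrogen and a dichlorophenyl. In this assay compound 2 likewise reports only a limit, > 100000 nM. Both values shown so far sit at the same place, (the limit of > 100000 nM in this assay, at which 2 of the 2 values shown sit), so compound 2 stands nowhere above the single point that the two measurements define; no number has yet been obtained in this series.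

Compound 3 `Cc1nn(C(=O)C2CCCC2)c(N)c1-c1ccc(Cl)c(Cl)c1` differs from compound 2 in one place: cyclopentyl in place of ethyl on a carbonyl carbon. Within the data shown here, no measured step between two compounds exists here to anchor the size of this change. With compound 2 itself resting at the limit, the expectation for this assay is no movement beyond the scatter, and no direction can be assigned.

Compound 3 is therefore estimated at 150000 nM, with a range from 30000 nM to 600000 nM. The step from compound 2 to compound 3 is estimated as a step that the limit leaves unreadable from compound 2 to compound 3, most likely ending again in a reported limit rather than a number.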

Compound 3, half-maximal inhibitory concentration: > 100000 nM
Compound 3: only a limit was reported (the forecaster's own chance of this, stated with the estimate: 85%); the middle value lies beyond the limit too.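

The change from compound 2 to compound 3 cannot be read, as both report only a limit. In this assay compound 3 gives > 100000 nM, which is a limit, and the series rests at one place: the limit of > 100000 nM in this assay, at which 3 of the 3 values shown sit.

The compounds shown leave open whether any member of this series gives a measurable inhibition in this assay.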